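The source may report more compounds than this note shows. Statements on the series, on what has been measured and on what is new or still open speak of the compounds shown alone.

Of the compounds shown here, two have been measured so far. Compound 1 `CC(CCc1ccc(-c2ccccc2)cc1)CC(=O)O` carries a biphenyl attached to a branched carboxylic acid chain. In an assay (strain CD) for inhibition of 3-hydroxy-3-methylglutaryl-coenzyme A reductase (Rattus norvegicus), read by scintillation counting, using microsomes, with a stated time of 90 min (on this read-out lower numbers stand for stronger inhibition and higher numbers for weaker inhibition), compound 1 gives 2000 nM, the lowest of the two numbers. Compound 2 `CC(CC(=O)O)CC(=O)c1ccc(Oc2ccccc2)cc1`, which bears a phenoxyphenyl on a chain that holds a carbonyl next to the ring, gives 290000 nM in this assay; its value is far above that of compound 1, well beyond the usual scatter of repeated measurements.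

The next compound keeps the chain of compound 1 unchanged and alters only the aromatic end. Compound 3 `CC(CCc1ccc(Oc2ccccc2)cc1)CC(=O)O` differs from compound 1 by phenoxy in place of phenyl on an aromatic carbon. Among the compounds with values here, no measured pair shows this exact change on its own, so the size of its effect is not known from the data. Compound 2 also carries a phenoxy group, but it differs from compound 3 in the chain as well, so it cannot settle the question.

The step from compound 1 to compound 3 is expected to be modest, toward a higher number, as a 2.0-fold higher number from compound 1 to compound 3 (0.30 log units; within the scatter). Compound 3 is therefore estimated at 4000 nM, with a likely range from 1000 nM to 20000 nM in this assay.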

Compound 3, half-maximal inhibitory concentration: 20000 nM
Estimate against measurement, compound 3: 5.0-fold (0.70 log units) below; the measured number falls inside the stated range.
By their numbers in this assay, from the lowest: compound 1; then compound 3; then compound 2.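

In this assay, the step of a 10-fold higher number from compound 1 to compound 3 (1.00 log units; beyond the scatter) shows that this aromatic carbon, para to a group of 8 heavy atoms, does not accept just any aromatic end equally: with the rest of the molecule held constant, phenoxy gives clearly weaker inhibition than phenyl. Within the data shown here, compound 2 could not show this, as it also differs from compound 1 in the chain, so this is the first measured comparison to isolate the aromatic end. The exchange is small on paper, since both groups hold one six-membered aromatic ring of carbon only and phenoxy adds one oxygen atom, yet it is enough to move the number beyond the usual scatter, though nothing available explains why.

The compounds shown leave open whether the oxygen atom itself matters or whether any added atom would do the same, a question that benzyl, with a carbon in the place of that oxygen, could address. They also leave open how smaller groups such as chloro or methoxy would fare on this same aromatic carbon.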